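Swapping Fluoro for Methoxy: From Compound 3 to Compound 4

A few compounds are considered here, and "the series" means these few. Any claim that something is new, unique, unknown or untested is made for them only; others in the source may bear on it.

Three compounds have been measured in an assay for inhibition of Fatty-acid amide hydrolase 1 (Mus musculus), read by scintillation counting; on this read-out lower numbers stand for stronger inhibition and higher numbers for weaker inhibition:

Compound 1 `C/C(=N\OC(=O)Nc1cccc2ccccc12)c1ccc(-c2ccccc2)cc1` gives 401 nM.
Compound 2 `C/C(=N\OC(=O)Nc1ccccc1)c1cccc(-c2ccccc2)c1` gives 69 nM.
Compound 3 `C/C(=N\OC(=O)Nc1ccc(F)cc1)c1cccc(-c2ccccc2)c1` gives 17 nM.

Compound 3 has the lowest number of the three, and so shows the strongest inhibition among them: compound 2 sits a step above it, and compound 1 sits further above, both gaps beyond the scatter of repeated measurements. Going by the values given here, the one single-change step so far, a 4.1-fold lower number from compound 2 to compound 3 (0.61 log units; beyond the scatter), is a fluoro in place of hydrogen on an aromatic carbon.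

Compound 4 `COc1ccc(NC(=O)O/N=C(\C)c2cccc(-c3ccccc3)c2)cc1` has not yet been measured. Its change from compound 3 is methoxy in place of fluoro on an aromatic carbon. Among the compounds with values here, the step from compound 2 to compound 3 touches the same position, but it tells what hydrogen and fluoro do there, not what methoxy does; no measured pair shows fluoro giving way to methoxy. The measured change at this position was modest, so a step of similar or smaller size is the most that the data support, with no clear direction. For compound 4 the expected value in this assay is 30 nM, with a range of 8 nM to 120 nM, which means an expected step of a 1.8-fold higher number from compound 3 to compound 4 (0.25 log units; within the scatter).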

Compound 4, half-maximal inhibitory concentration: 28 nM
For compound 4 the middle estimate is 1.1-fold (0.03 log units) above the measured one; low and high end bracket the measured number.
By their numbers in this assay, from the lowest: compounds 3 and 4 (each within the scatter of the next); then compound 2; then compound 1.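

In this assay, the step is a 1.6-fold higher number from compound 3 to compound 4 (0.22 log units; within the scatter), so this position tolerates the exchange of fluoro, with 1 heavy atom and no hydrogen-bond acceptor, for methoxy, with 2 heavy atoms and 1 hydrogen-bond acceptor, without a change that can be told from the scatter. The second comparison, a 2.5-fold lower number from compound 2 to compound 4 (0.39 log units; beyond the scatter), shows that the earlier gain over hydrogen is not confined to fluoro: among compounds 2, 3 and 4, both groups placed here give a lower number than hydrogen does. Nothing available explains why these two quite different groups give values that cannot be separated, and no measured property of either group bears on the result.

Going by these compounds, what remains open is how far this tolerance extends, since an amine, a carboxylic acid or a longer chain such as butoxy at the same position could give a number close to these or a very different one. The compounds shown also leave open whether fluoro or methoxy would give a similar gain over hydrogen at other places on this ring.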